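The source may report more compounds than this note shows. Statements on the series, on what has been measured and on what is new or still open speak of the compounds shown alone.

Measured so far in a functional assay on HL-60 cells (Homo sapiens) for antiproliferative activity, read by MTT assay, with a stated time of 72 h; a lower number here means a stronger inhibitor, a higher number a weaker inhibitor:

Compound 1 `CN(c1ccc2[nH]c(-c3n[nH]c4ccccc34)cc2n1)S(=O)(=O)c1ccccc1` gives 3700 nM.
Compound 2 `COc1ccc(S(=O)(=O)N(C)c2ccc3[nH]c(-c4n[nH]c5ccccc45)cc3n2)cc1` gives 4340 nM.
Compound 3 `CN(C(=O)Nc1ccccc1)c1ccc2[nH]c(-c3n[nH]c4ccccc34)cc2n1` gives 8.3 nM.

Two structural changes connect these three compounds. The first is methoxy in place of hydrogen on an aromatic carbon, and it made a step of a 1.2-fold higher number from compound 1 to compound 2 (0.07 log units; within the scatter). The second is phenylcarbamoyl in place of phenylsulfonyl on a nitrogen on an aromatic ring, and that step was a 450-fold lower number from compound 1 to compound 3 (2.65 log units; beyond the scatter); this is also how the core of compound 1 differs from the core of compound 3.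

Compound 4 `COc1ccc(NC(=O)N(C)c2ccc3[nH]c(-c4n[nH]c5ccccc45)cc3n2)cc1` has not yet been measured. Going by the values given here, it differs from compound 3 by methoxy in place of hydrogen on an aromatic carbon, which is the same change as the one from compound 1 to compound 2, made at the same kind of place. Since that earlier step was a 1.2-fold higher number from compound 1 to compound 2 (0.07 log units; within the scatter), the step from compound 3 to compound 4 is expected to be similar, a 1.2-fold higher number from compound 3 to compound 4 (0.08 log units; within the scatter). Compound 4 is therefore estimated at 10 nM, with a range from 4 nM to 25 nM.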

Compound 4, half-maximal inhibitory concentration: 7.9 nM
For compound 4 the middle estimate is 1.3-fold (0.10 log units) above the measured one; the measured number falls inside the stated range.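

In this assay, methoxy in place of hydrogen gives a 1.1-fold lower number from compound 3 to compound 4 (0.02 log units; within the scatter). Set beside the same change on the core of compound 1, the two steps agree: the same change on two cores in this assay, a 1.2-fold higher number (0.07 log units; within the scatter) from compound 1 to compound 2 and a 1.1-fold lower number (0.02 log units; within the scatter) from compound 3 to compound 4, 1.2-fold (0.09 log units) apart, within the scatter of two such steps. Going by these compounds alone, in these two pairs, then, the change leaves the number within the scatter on both cores, even though compound 3 and compound 1 differ widely in activity; this is only two pairs with one group, so it does not establish a rule for other cores or explain the result.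

Still open, going by these compounds, is whether an amine, a carboxylic acid or a longer chain such as butoxy at the same place would also leave the number unmoved. On these data alone, it is also open whether methoxy would do so on other carbons of that ring.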